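Cyano in Place of Nitro on Compound 2

A few compounds are considered here, and "the series" means these few. Any claim that something is new, unique, unknown or untested is made for them only; others in the source may bear on it.

Of the compounds shown here, three have been measured in an ADME assay on MEpiC cells (Homo sapiens) for antiproliferative activity, read by MTT assay, with a stated time of 48 h; on this read-out higher numbers stand for weaker inhibition and lower numbers for stronger inhibition. Compound 1 `COc1ccc(OC(=O)C#Cc2ccccc2)cc1` gives 19100 nM in this assay. Compound 3 `COc1cc(C2=C(c3ccccc3)C3(C=CC(=O)C=C3)OC2=O)cc(OC)c1OC` gives 6610 nM in this assay. Compound 2 `O=C1C=CC2(C=C1)OC(=O)C(c1ccc([N+](=O)[O-])cc1)=C2c1ccccc1` gives 66600 nM in this assay, the highest of the three numbers; the nearest number belongs to compound 1 and the furthest to compound 3, and both gaps lie beyond the usual scatter. Compound 2 and compound 3 share a core and differ in the substituents on one phenyl ring.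

Compound 4 `N#Cc1ccc(C2=C(c3ccccc3)C3(C=CC(=O)C=C3)OC2=O)cc1` has not yet been measured. It differs from compound 2 in one place: cyano in place of nitro on an aromatic carbon. Within the data shown here, no pair of measured compounds shows this exchange, so its effect cannot be read from any measured step. The exchange of one small group for another at the same place is expected to move the number only modestly in this assay, most likely within or just beyond the scatter, and a small decrease is taken as the more probable direction. The step expected from compound 2 to compound 4 is a 1.7-fold lower number from compound 2 to compound 4 (0.22 log units; within the scatter). Compound 4 is accordingly estimated at 40000 nM in this assay, within a range from 12000 nM to 130000 nM.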

Compound 4, half-maximal inhibitory concentration: 8890 nM
Compound 4: middle estimate off by 4.5-fold (0.65 log units), on the high side, outside the stated range (below it).
By their numbers in this assay, from the lowest: compounds 3 and 4 (each within the scatter of the next); then compound 1; then compound 2.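

In this assay, among these compounds, the change from 4-nitrophenyl to 4-cyanophenyl gives a 7.5-fold lower number from compound 2 to compound 4 (0.87 log units; beyond the scatter) and is the only step here that isolates a single place. Among the compounds shown here, it shows that this aromatic carbon, para to a large group, is not indifferent to the group it carries: with the shared core held constant, exchanging nitro for cyano alone moves the number beyond the usual scatter, something the earlier compounds could not show on their own. No measurement shown here accounts for the size of this step or tells which difference between nitro and cyano matters.

Going by these compounds, whether the number at this place follows any trend remains open, as a single exchange cannot establish one, and an amine, a carboxylic acid or a fluorine atom on the same aromatic carbon could sit anywhere relative to compound 2 and compound 4. On these data alone, it also remains open whether cyano in place of nitro would produce a step of similar size and the same direction on a different core.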